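Adding a chlorine to the urea phenyl of compound 1

The source may hold more compounds than are shown below. What is called first, only, known or untested is meant among the compounds shown, and "the series" means these compounds.

Measured so far:
compound 1, `CC1(C)CC(NC(=O)Nc2ccccc2)c2cc(Cl)ccc2O1`: 34000 nM
compound 2, `CCNC(=S)NC1CC(C)(C)Oc2ccc(Cl)cc21`: > 100000 nM

Compound 1 carries a urea linking its core to a plain phenyl ring. Within the data shown here, in a functional assay on T98G cells (Homo sapiens) for inhibition, read by MTT assay, with a stated time of 72 h (a higher number here means a weaker inhibitor, a lower number a stronger inhibitor), compound 1 gives 34000 nM, the only full number in this small set. Compound 2, a thiourea with an ethyl group instead of the phenyl, reaches only a limit of the assay; in this assay compound 2 gives > 100000 nM, which is a limit and not a number. Among the measured compounds shown here, that limit, (the limit of > 100000 nM in this assay, at which 1 of the 2 values shown sits), is the only other reading here, so no step between measured compounds can be sized.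

Compound 3, `CC1(C)CC(NC(=O)Nc2ccccc2Cl)c2cc(Cl)ccc2O1`, differs from compound 1 by one change: chloro in place of hydrogen on an aromatic carbon. The new chlorine sits on the phenyl ring attached to the urea. For the measured compounds named here, with no measured step of this kind to lean on, the expectation is a step that stays within the usual scatter, perhaps leaning slightly toward stronger inhibition. The expected step in this assay is a 1.4-fold lower number from compound 1 to compound 3 (0.13 log units; within the scatter). Compound 3 is therefore estimated to give 25000 nM in this assay, with a range from 8000 nM to 80000 nM.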

Compound 3, half-maximal inhibitory concentration: 20000 nM
Compound 3: middle estimate off by 1.3-fold (0.10 log units), on the high side, within the range that was stated.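

In this assay, among these compounds, this gives the first measured step on the phenyl ring of the urea: a 1.7-fold lower number from compound 1 to compound 3 (0.23 log units; within the scatter). The two compounds therefore cannot be told apart, and chloro in place of hydrogen on this aromatic carbon, ortho to a large group, is accommodated without any measurable loss of inhibition, though also without a measurable gain. Nothing among the measurements shown explains why the number stays where it does.

From the compounds shown here alone, whether a methoxy group, an amine or a carboxylic acid on that same aromatic carbon would carry the number beyond the scatter remains open, as does the reading of a chloro elsewhere on the phenyl ring. Going by these compounds, compound 2 differs from compound 1 in more than one place and its reading is a limit, so the separate contributions of the urea and of the phenyl ring also remain open.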